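The source may report more compounds than this note shows. Statements on the series, on what has been measured and on what is new or still open speak of the compounds shown alone.

Compound 1, `CCCC(=O)N(Cc1ccccc1)C1CCN(S(=O)(=O)c2c(C)cc(C)cc2C)CC1`: > 5000 nM in an ADME assay on HCT-116 cells (Homo sapiens) for cytotoxicity, read by CellTiter-Glo, with a stated time of 72 h; a higher number here means a weaker inhibitor, a lower number a stronger inhibitor
Compound 2, `CC1CCN(C2CCN(S(=O)(=O)c3cccc4ccccc34)CC2)CC1`: > 10000 nM in this assay

Neither reading is a number. For compound 1 the reading of > 5000 nM is a limit of this assay, (the limit of > 5000 nM in this assay, at which 1 of the 2 values shown sits). For compound 2 the reading of > 10000 nM is likewise a limit of this assay, (the limit of > 10000 nM in this assay, at which 1 of the 2 values shown sits). Compound 1 thus stands at a limit, as does the only other compound shown, and no step between the two can be sized, since no single change links them and neither has a measured number.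

Compound 3, `CCCC(=O)NC1CCN(S(=O)(=O)c2c(C)cc(C)cc2C)CC1`, has not yet been measured in this assay. It differs from compound 1 in one place: hydrogen in place of benzyl on an amide-type nitrogen. No measured pair with this change is shown, so the size of the step rests on the two limits alone. The estimated step is a step that the limit leaves unreadable from compound 1 to compound 3, which is expected to lie within the scatter of this assay, in no particular direction. Compound 3 is therefore estimated at 9000 nM in this assay, with a range from 3000 nM to 30000 nM, and is expected most likely to return a limit rather than a number.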

Compound 3, half-maximal inhibitory concentration: > 5000 nM
Compound 3 ended at the assay's limit; the forecaster's own chance of this, stated with the estimate: 80%; the middle value is on the limit's open side.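

Compound 1 and compound 3 both end at a limit in this assay, so no step can be read between them: the limit of > 5000 nM in this assay, at which 2 of the 3 values shown sit.

The compounds shown leave open whether hydrogen in place of benzyl on the amide-type nitrogen changes cytotoxicity at all, and what numerical value any of these compounds would return.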